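A few compounds are considered here, and "the series" means these few. Any claim that something is new, unique, unknown or untested is made for them only; others in the source may bear on it.

In a functional assay on A549 cells (Homo sapiens) for antiproliferative activity, read by MTT assay, with a stated time of 24 h (a higher number here means a weaker inhibitor, a lower number a stronger inhibitor), two compounds have been tested so far. Compound 1 `C=CCc1cc(-c2cccc(C(F)(F)F)c2)ccc1O`, which carries an allyl group and a trifluoromethyl group, gives 73000 nM. Compound 2 `C=CCc1cc(C=O)c(OCC(=O)OCC)c(-c2ccc(OCC(=O)OCC)c(CC=C)c2)c1` carries allyl groups, (ethoxycarbonyl)methoxy groups and a formyl group. For compound 2 the assay returned only a limit, > 85800 nM, and not a number.

Compound 3 `C=CCc1ccc(OCC(=O)OCC)c(-c2ccc(OCC(=O)OCC)c(CC=C)c2)c1` has not yet been measured. It is compound 2 with hydrogen in place of formyl on an aromatic carbon, ortho to a (ethoxycarbonyl)methoxy group and meta to an allyl group: hydrogen in place of formyl on an aromatic carbon.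

As far as these compounds go, compounds 1 and 2 differ in many places, so no single change has a measured size here, and what the formyl group contributes is unknown. Among the compounds with values here, with compound 1 at 73000 nM as the only true number, a large gain in this assay is not expected, and the expectation is no change beyond the usual scatter. The estimate amounts to an at least 1.0-fold lower number from compound 2 to compound 3 (0.03 log units; that floor lies within the scatter), which is expected to remain small. The estimated value for compound 3 is 80000 nM, with an expected range from 30000 nM to 200000 nM.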

Compound 3, half-maximal inhibitory concentration: > 91300 nM
Compound 3: only a limit was reported (the forecaster's own chance of this, stated with the estimate: 55%); middle value at least 1.1-fold (0.05 log units) from the limit.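

In this assay, compound 2 and compound 3 each returned only a limit and not a number, so the step between them cannot be read. The compounds shown leave open whether hydrogen in place of formyl on that aromatic carbon changes antiproliferative activity at all, and in which direction.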